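A Hydroxyphenyl Arm in Place of a Naphthyl Arm

The source may report more compounds than this note shows. Statements on the series, on what has been measured and on what is new or still open speak of the compounds shown alone.

Compound 3 `Cc1nc2c3ccccc3ccc2c2nc3c(ccc4ccccc43)c(-c3cccc4ccccc34)c12` was tested in a functional assay on HCT-116 cells (Homo sapiens) for cytotoxicity, read by MTT assay, with a stated time of 48 h (on this read-out lower numbers stand for stronger inhibition and higher numbers for weaker inhibition), where compound 3 gives 20800 nM. Among the three measured compounds this is the second highest number: compound 1 `Cc1nc2c3ccccc3ccc2c2nc3c(ccc4ccccc43)c(-c3ccccc3Cl)c12` gives 48200 nM, and compound 2 `Cc1nc2c3ccccc3ccc2c2nc3c(ccc4ccccc43)c(-c3nccnc3N)c12` gives 3560 nM. The step of a 2.3-fold lower number from compound 1 to compound 3 (0.36 log units; beyond the scatter) is modest, and a 5.8-fold higher number from compound 2 to compound 3 (0.77 log units; beyond the scatter) is also modest but runs the other way, so compound 3 sits between its two neighbours.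

Compound 4 `Cc1nc2c3ccccc3ccc2c2nc3c(ccc4ccccc43)c(-c3ccc(O)cc3)c12` differs from compound 3 in one place: 4-hydroxyphenyl in place of naphthalen-1-yl on an aromatic carbon. Among the measured compounds shown here, two measured steps bear on this change. Going from 2-chlorophenyl to naphthalen-1-yl gave a 2.3-fold lower number from compound 1 to compound 3 (0.36 log units; beyond the scatter), which on its own would suggest that a single ring returns a higher number. Yet the entering group brings one hydrogen-bond donor and one hydrogen-bond acceptor, as 3-aminopyrazin-2-yl does, and a 5.8-fold higher number from compound 2 to compound 3 (0.77 log units; beyond the scatter) shows that group going with the lowest number of the set. Weighing both, a modest step downward is expected, a 2.1-fold lower number from compound 3 to compound 4 (0.32 log units; beyond the scatter). Compound 4 is therefore estimated at 10000 nM, with a range from 3000 nM to 35000 nM.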

Compound 4, half-maximal inhibitory concentration: 3190 nM
Beside the measured number, compound 4's estimate is 3.1-fold (0.50 log units) above it, within the range that was stated.
By their numbers in this assay, from the lowest: compounds 4 and 2 (each within the scatter of the next); then compound 3; then compound 1.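

In this assay, a single ring carrying a hydroxyl does more here than the larger two-ring arm, with a 6.5-fold lower number from compound 3 to compound 4 (0.81 log units; beyond the scatter) as the step, so a second fused ring is not needed at this position to reach the low end of the set. The arm need not be a nitrogen-containing ring either: a 1.1-fold lower number from compound 2 to compound 4 (0.05 log units; within the scatter) leaves 4-hydroxyphenyl and 3-aminopyrazin-2-yl level, while a 15-fold lower number from compound 1 to compound 4 (1.18 log units; beyond the scatter) shows that a single ring alone does not set the number, as 2-chlorophenyl is also one. Across these four compounds, the two arms with a hydrogen-bond donor give the lower numbers, with no compound going against this, but no measurement here explains that link.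

Going by these compounds, whether the hydroxyl itself drives the change remains open, as a plain phenyl or a methoxy group in its place would test. An amine or a carboxylic acid on the same phenyl ring is also an open question.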